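Swapping hydroxy for fluoro on two acetylated diol scaffolds

This account rests on a few compounds, and the source may have more. Where it says the series, first, only, none or still open, it means among the compounds named here.

Measured so far:
- Compound 1, `COc1nc(CC(O)(COC(C)=O)COC(C)=O)c(C)c(OC)n1`, in a functional assay on MIA PaCa-2 cells (Homo sapiens) for antiproliferative activity, read by MTT assay, with a stated time of 72 h (a lower number here means a stronger inhibitor, a higher number a weaker inhibitor), gives > 100000 nM, which is a limit of the assay rather than a number.
- Compound 2, `COc1nc(CC(F)(COC(C)=O)COC(C)=O)c(C)c(OC)n1`, in this assay gives > 100000 nM, again a limit.
- Compound 3, `CC(=O)OCC(O)(COC(C)=O)Cc1c(C)c(=O)[nH]c(=O)n1C`, in this assay gives > 100000 nM, also a limit.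

Compound 1 and compound 2 share one core and differ in a single place: fluoro in place of hydroxy on a saturated chain carbon bound to three saturated chain carbons. The step that the two limits leave unreadable from compound 1 to compound 2 cannot be read, since both ends sit at a limit. Among the measured compounds shown here, the only evidence on this change is therefore (the limit of > 100000 nM in this assay, at which 3 of the 3 values shown sit), and it says nothing about direction or size.

Compound 3 carries a different core; the difference between the two cores is not broken down here. Compound 4, `CC(=O)OCC(F)(COC(C)=O)Cc1c(C)c(=O)[nH]c(=O)n1C`, has not yet been measured. It differs from compound 3 by fluoro in place of hydroxy on a saturated chain carbon bound to three saturated chain carbons, and the place is described in the same words as for the pair of compound 1 and compound 2, so this is the same change made on the other core.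

For compound 4 the expectation rests on compound 3 sitting at the limit and on the same change leaving compound 2 at the limit as well: the step of a number no higher from compound 3 to compound 4 (the limit leaves the size open) is expected to be unreadable in the same way. Compound 4 is therefore estimated at 100000 nM in this assay, most likely reported again only as a limit, with a spread from 30000 nM to 300000 nM.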

Compound 4, half-maximal inhibitory concentration: > 100000 nM
Compound 4 ended at the assay's limit; the forecaster's own chance of this, stated with the estimate: 85%; the middle value lies on the limit itself.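

Compound 3 and compound 4 both end at a limit rather than at a number, so no step can be read between them, and the same holds for compound 1 and compound 2: the limit of > 100000 nM in this assay, at which 4 of the 4 values shown sit. The compounds shown leave open whether fluoro in place of hydroxy changes the result in this assay at all, and in which direction, on either core.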